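From carboxy to (3-chlorophenyl)carbamoyl on compound 1

The compounds below may be only part of what the source reports. "The series", "measured", "known", "first", "only" and "open" are said of these compounds alone.

- compound 1 (`O=C(O)CCCCC(CCSC(=O)c1ccccc1)SC(=O)c1ccccc1`): 2.68%
- compound 2 (`O=C(CCCCC1CCSS1)Nc1ccccc1Cl`): "not active" (no number reported)
- compound 3 (`O=C(CCCCC(S)CCS)Nc1ccc(OC(F)(F)F)cc1`): 15%

All three compounds were tested in a functional assay on KB cells (Homo sapiens) for inhibition, read by MTT assay, with a stated time of 24 h, tested at 10 ug/mL (a higher number here means more inhibition of growth at the concentration tested, a lower number less inhibition of growth), and compound 1 stands low there. With its reading of 2.68% as the lower of the two numbers available, compound 1 sits below compound 3 at 15% by a gap beyond the scatter. Compound 2 is reported as "not active" (no number reported) without a number and cannot be placed on that scale.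

The next compound, compound 4 (`O=C(CCCCC(CCSC(=O)c1ccccc1)SC(=O)c1ccccc1)Nc1cccc(Cl)c1`), has not yet been measured. It keeps the core of compound 1 and carries (3-chlorophenyl)amino in place of hydroxy on a carbonyl carbon. Among the measured compounds shown here, no measured pair isolates this change, so the guidance is indirect. Compound 3 at 15% and compound 2 at "not active" (no number reported) are also amides at that carbonyl carbon, yet they disagree with each other and differ from compound 4 elsewhere. Only a small upward move, not beyond the scatter, is expected in this assay on this evidence. The estimated change is a number 7.3 percentage points higher from compound 1 to compound 4 (within the scatter) and remains modest. For compound 4 the estimate is 10% with an expected range from 0% to 30% and a report without a number remains possible.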

Compound 4, percent growth inhibition at one concentration: 16.6%
The estimate for compound 4 lay 6.6 percentage points below the measured number; low and high end bracket the measured number.
By their numbers in this assay, from the lowest: compound 1; then compounds 3 and 4 (each within the scatter of the next).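

In this assay, the exchange of hydroxy for (3-chlorophenyl)amino on a carbonyl carbon whose other neighbour is a saturated chain carbon can now be read on its own, as a number 13.9 percentage points higher from compound 1 to compound 4 (beyond the scatter). The earlier amides, compound 2 and compound 3, also differ from compound 1 elsewhere, whereas compound 4 keeps the core of compound 1, so this step shows that, on that core, the position accepts the larger group in place of hydroxy, with a modest gain in growth inhibition rather than a loss. No measurement at hand accounts for this step, so the reason for it remains unknown.

The compounds shown leave open whether the gain depends on the chlorine, on the aromatic ring or on the amide link itself, a question that phenylamino, benzylamino or a methyl ester on the same carbonyl carbon would help to separate. They also leave open how the benzoyl groups of the shared core bear on this change, since a matching 3-chlorophenyl amide with two free thiols is not among them.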